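The source may report more compounds than this note shows. Statements on the series, on what has been measured and on what is new or still open speak of the compounds shown alone.

Compound 1, `O=C(Nc1cc(-c2ccccc2)[nH]n1)c1cncc(Br)c1`, gives 19300 nM in a functional assay on WM1361 cells (Homo sapiens) for antiproliferative activity, read by MTT assay, with a stated time of 48 h; a lower number here means a stronger inhibitor, a higher number a weaker inhibitor.
Compound 2, `O=C(Nc1cc(-c2ccccc2)[nH]n1)c1ccc(Br)nc1`, gives 19400 nM in this assay.
Compound 3, `Cc1ccc(-c2cc(NC(=O)c3cncc(Br)c3)n[nH]2)cc1`, gives 17900 nM in this assay.

All three measured compounds are weak inhibitors, and their numbers sit close together. The change from compound 1 to compound 2, (6-bromopyridin-3-yl in place of 5-bromopyridin-3-yl on a carbonyl carbon), gave a 1.0-fold higher number from compound 1 to compound 2 (0.00 log units; within the scatter). The change from compound 1 to compound 3, (methyl in place of hydrogen on an aromatic carbon), gave a 1.1-fold lower number from compound 1 to compound 3 (0.03 log units; within the scatter). Neither change moved the number out of the scatter.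

Compound 4, `Cc1ccc(-c2cc(NC(=O)c3ccc(Br)nc3)n[nH]2)cc1`, has not yet been measured. It differs from compound 3 by 6-bromopyridin-3-yl in place of 5-bromopyridin-3-yl on a carbonyl carbon, which is the same change already seen between compound 1 and compound 2, made at the same place. The cores of compound 1 and compound 3 differ by methyl in place of hydrogen on an aromatic carbon.

The step from compound 3 to compound 4 is expected to be a 1.0-fold higher number from compound 3 to compound 4 (0.00 log units; within the scatter), an expectation that rests on the step of a 1.0-fold higher number from compound 1 to compound 2 (0.00 log units; within the scatter) seen for the same change. Compound 4 is therefore estimated to give 18000 nM in this assay, with a likely range from 9000 nM to 36000 nM.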

Compound 4, half-maximal inhibitory concentration: 18600 nM
Beside the measured number, compound 4's estimate is 1.0-fold (0.01 log units) below it, within the range that was stated.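

Within the data shown here, on the core that carries the methyl, 6-bromopyridin-3-yl in place of 5-bromopyridin-3-yl gave a 1.0-fold higher number from compound 3 to compound 4 (0.02 log units; within the scatter), and this matches what the same change did on the core of compound 1: the same change on two cores in this assay, a 1.0-fold higher number (0.00 log units; within the scatter) from compound 1 to compound 2 and a 1.0-fold higher number (0.02 log units; within the scatter) from compound 3 to compound 4, 1.0-fold (0.01 log units) apart, within the scatter of two such steps Read the other way, methyl in place of hydrogen on an aromatic carbon gave a 1.0-fold lower number from compound 2 to compound 4 (0.02 log units; within the scatter), and this too matches the earlier step: the same change on two cores in this assay, a 1.1-fold lower number (0.03 log units; within the scatter) from compound 1 to compound 3 and a 1.0-fold lower number (0.02 log units; within the scatter) from compound 2 to compound 4, 1.0-fold (0.01 log units) apart, within the scatter of two such steps So in this assay both changes carry from one core to the other as steps within the scatter, but this shows only that neither change shifts the number on these two cores, not that a step of real size would carry over in the same way, nor that the same would hold on any other core.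

The compounds shown leave open whether any change to this series can move the number beyond the scatter. An amine or a carboxylic acid in place of the bromine, or a longer chain in place of the methyl, would be a first test of that.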